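A second chloro on the shared core

A few compounds are considered here, and "the series" means these few. Any claim that something is new, unique, unknown or untested is made for them only; others in the source may bear on it.

compound 1 `O=c1c(-c2nn[nH]n2)c[nH]c2ccc(F)cc12`: > 20 mg/kg
compound 2 `O=c1c(-c2nn[nH]n2)c[nH]c2ccc(Cl)cc12`: > 25 mg/kg

Of the compounds shown here, two of the shared core have been tested in a functional assay on the whole organism (strain Sprague-Dawley) for inhibition, with Rattus norvegicus as the target; on this read-out lower numbers stand for an effect already at smaller amounts and higher numbers for an effect only at larger amounts of compound. For compound 1 the result in this assay is only a limit, > 20 mg/kg. For compound 2 the result in this assay is likewise only a limit, > 25 mg/kg. The step that the two limits leave unreadable from compound 1 to compound 2 therefore cannot be read, since one value sits at the limit of > 20 mg/kg in this assay, at which 1 of the 2 values shown sits, and the other at the limit of > 25 mg/kg in this assay, at which 1 of the 2 values shown sits. Compound 2 thus stands at a limit, with no number of its own and nothing to rank it against compound 1.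

Compound 3 `O=c1c(-c2nn[nH]n2)c[nH]c2c(Cl)cc(Cl)cc12` is not yet measured. It differs from compound 2 by chloro in place of hydrogen on an aromatic carbon. Within the data shown here, no measured step in this set describes adding a chloro group on the shared core, and the only step available is itself unreadable. There is thus no basis for expecting a shift beyond the scatter, and the step that the limit leaves unreadable from compound 2 to compound 3 is estimated as small. Compound 3 is expected to give about 30 mg/kg in this assay, within 10 mg/kg to 100 mg/kg, most likely again reported only as a limit.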

Compound 3, minimum effective dose: > 10 mg/kg
Compound 3: only a limit was reported; the forecaster's own chance of this, stated with the estimate: 70%; the middle value lies beyond the limit too.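

For compound 3 the result in this assay is again only a limit, > 10 mg/kg. Compound 2 and compound 3 therefore both stand at limits, and the step between them cannot be read. The compounds shown leave open what number any of them would reach in this assay, and whether chloro in place of hydrogen on an aromatic carbon changes the result at all.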